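A few compounds are considered here, and "the series" means these few. Any claim that something is new, unique, unknown or untested is made for them only; others in the source may bear on it.

Measured so far:
- compound 1, `CCCS(=O)(=O)Nc1ccc(Cl)c(C(=O)Nc2cnc3[nH]nc(OC)c3c2)c1F`
- compound 2, `CCCS(=O)(=O)Nc1ccc(F)c(C(=O)Nc2cnc3[nH]ncc3c2)c1F`

Going by the values given here, in a physicochemical assay for solubility, read by HPLC, in phosphate buffer, with a stated time of 24 h, at pH 6.5 (on this read-out lower numbers stand for lower solubility and higher numbers for higher solubility), compound 2 gives 80 ug/mL, the only number in the set. Compound 1 sits at a limit of this assay, < 1 ug/mL; see (the limit of < 1 ug/mL in this assay, at which 1 of the 2 values shown sits). Compound 3, `CCCS(=O)(=O)Nc1ccc(Cl)c(C(=O)Nc2cnc3[nH]ncc3c2)c1F`, is not yet measured. It differs from compound 2 by chloro in place of fluoro on an aromatic carbon. Among the compounds with values here, no measured pair isolates this change, so the size of the step is uncertain. A downward step a 2.7-fold lower number from compound 2 to compound 3 (0.43 log units; beyond the scatter) is expected, beyond the scatter but short of a limit. Compound 3 is estimated at 30 ug/mL, within the range 8 ug/mL to 80 ug/mL.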

Compound 3, solubility: 15 ug/mL
Compound 3: middle estimate off by 2.0-fold (0.30 log units), on the high side; the measured number falls inside the stated range.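

In this assay, chloro in place of fluoro on an aromatic carbon, para to a (propylsulfonyl)amino group, now has a measured size: a 5.3-fold lower number from compound 2 to compound 3 (0.73 log units; beyond the scatter). With chloro held in place, hydrogen in place of methoxy on an aromatic carbon gives an at least 15-fold higher number from compound 1 to compound 3 (1.17 log units; beyond the scatter). Compound 1 stands at a limit, so this step has one open end: the limit of < 1 ug/mL in this assay, at which 1 of the 3 values shown sits.

Still open, as far as these compounds go, is the size of the methoxy step with fluoro in place of chloro. Also open, from the compounds shown here alone, is how a nitrile or an amine in place of the chloro would read in this assay.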